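A few compounds are considered here, and "the series" means these few. Any claim that something is new, unique, unknown or untested is made for them only; others in the source may bear on it.

Working notes on the quinone ether series.

Three compounds carry measurements in a functional assay on HeLa cells (Homo sapiens) for cytotoxicity; a higher number here means a weaker inhibitor, a lower number a stronger inhibitor. Compound 1 `O=C(Oc1ccc2c(c1)C(=O)C=CC2=O)c1ccccc1` gives 19200 nM. Compound 2 `C=CCOc1ccc2c(c1)C(=O)C=CC2=O` gives 27200 nM. Compound 3 `O=C1C=CC(=O)c2cc(OCc3ccccc3)ccc21` gives 16800 nM. Among the three, compound 2 holds the highest number, but its gap to compound 1 and its gap to compound 3 both fall inside the usual scatter, so no real ordering of the three can be claimed. Within the data shown here, the single one-point step so far, phenyl in place of vinyl on a saturated chain carbon bound to an oxygen on the aromatic ring, reads a 1.6-fold lower number from compound 2 to compound 3 (0.21 log units; within the scatter) and is within the scatter.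

Compound 4 `O=C1C=CC(=O)c2cc(Oc3cccs3)ccc21` is the next member, not yet measured in this assay. Relative to compound 2 the change is thiophen-2-yl in place of allyl on an oxygen on an aromatic ring. Among the measured compounds shown here, no measured step covers an aromatic group placed directly on the ether oxygen; the closest precedent, the step of a 1.6-fold lower number from compound 2 to compound 3 (0.21 log units; within the scatter), put an aromatic ring one saturated carbon further out and moved the number little. On that footing, and with all three measured numbers clustered closely, a step of a 1.4-fold lower number from compound 2 to compound 4 (0.13 log units; within the scatter) is expected, not beyond the scatter. The estimate for compound 4 in this assay is 20000 nM, within 8000 nM to 50000 nM.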

Compound 4, half-maximal inhibitory concentration: 8860 nM
Estimate against measurement, compound 4: 2.3-fold (0.35 log units) above, within the range that was stated.
By their numbers in this assay, from the lowest: compounds 4, 3, 1 and 2 (each within the scatter of the next, the first and the last beyond it).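

In this assay, the change on an oxygen on an aromatic ring now gives a step beyond the scatter (a 3.1-fold lower number from compound 2 to compound 4 (0.49 log units; beyond the scatter)), whereas the earlier step at this place stayed within it (a 1.6-fold lower number from compound 2 to compound 3 (0.21 log units; within the scatter)). The number at this position can therefore respond to the group on the oxygen, and thiophen-2-yl in place of allyl is the first change shown to do so, although the step is modest and compound 4 stays within the scatter of compound 3. No measurement shown here bears on why this change moves the number.

On these data alone, it remains open whether the step belongs to thiophen-2-yl itself or to any aromatic ring set directly on the oxygen, a question that phenyl or furan-2-yl at the same place would address. Also open, as far as these compounds go, is how far this position tolerates other kinds of group, such as a chain ending in an amine or a carboxylic acid, and whether either would move the number in the same direction as thiophen-2-yl.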